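Chain variation at the ether carbon: compound 1 to compound 4

The compounds below may be only part of what the source reports. "The series", "measured", "known", "first", "only" and "open" are said of these compounds alone.

Measured compounds in an ADME assay on microsomes from liver (Homo sapiens) for metabolic stability; on this read-out higher numbers stand for fast clearance and lower numbers for slow clearance:
compound 1 `O=C(O)CCNC(=O)c1ccc(C(Oc2ccc(-n3cc(C(F)(F)F)cn3)cc2)C2CC2)cc1`: < 8 mL/min/kg
compound 2 `CCCC(Oc1ccc(-n2cc3ccccc3n2)cc1)c1ccc(C(=O)NCCC(=O)O)cc1`: 44 mL/min/kg
compound 3 `CCCC(Oc1ccc(-n2cc(C(F)(F)F)c(C)n2)cc1)c1ccc(C(=O)NCCC(=O)O)cc1`: < 10 mL/min/kg

Compound 1 gives < 8 mL/min/kg in this assay, which is a limit of the assay and not a number (the limit of < 8 mL/min/kg in this assay, at which 1 of the 3 values shown sits). Compound 3 also sits at a limit, < 10 mL/min/kg (the limit of < 10 mL/min/kg in this assay, at which 1 of the 3 values shown sits). Compound 2 gives 44 mL/min/kg in this assay. Going by the values given here, the only step between measured compounds, an at least 4.4-fold lower number from compound 2 to compound 3 (0.64 log units; beyond the scatter), concerns the aromatic group on the ether oxygen and not the chain carbon.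

Compound 4 `CC(C)CC(Oc1ccc(-n2cc(C(F)(F)F)cn2)cc1)c1ccc(C(=O)NCCC(=O)O)cc1` differs from compound 1 by isobutyl in place of cyclopropyl on a saturated chain carbon bound to an aromatic carbon and an oxygen on an aromatic ring. Among the compounds with values here, no measured step touches this position, so the measured compounds give no direct size for the change. Compound 3 carries a propyl at the same carbon and sits at a limit, < 10 mL/min/kg. On that basis compound 4 is expected to remain at the slow end, with an estimate of 12 mL/min/kg and a range of 5 mL/min/kg to 30 mL/min/kg. The expected step of an at least 1.5-fold higher number from compound 1 to compound 4 (0.17 log units; that floor lies within the scatter) is estimated to lie within the scatter.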

Compound 4, clearance in the Homo sapiens assay: 23 mL/min/kg
The estimate for compound 4 lay 1.9-fold (0.28 log units) below the measured number; the range from low to high includes it.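

Going by these compounds alone, in the Homo sapiens assay, isobutyl in place of cyclopropyl on this saturated chain carbon gives the first measured step at this position, an at least 2.8-fold higher number from compound 1 to compound 4 (0.45 log units; beyond the scatter), so the group here does register in clearance. In the Homo sapiens assay compound 1 stands at < 8 mL/min/kg, a limit of the assay and not a number, so the step gives only a floor for the size of the change. In a physicochemical assay for lipophilicity, using the shake flask method, at pH 7.4 (on this read-out higher numbers stand for higher lipophilicity and lower numbers for lower lipophilicity), compound 1 gives 1.7 and compound 4 gives 3.2, so both read-outs rise together across this one pair.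

A single pair cannot separate the loss of the cyclopropyl ring from the change in chain, nor show whether clearance follows the distribution coefficient at this carbon. A cyclobutyl or a methoxyethyl group at this carbon would bear on both questions.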